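Swapping a saturated ring for an aromatic one: what to expect

The compounds below may be only part of what the source reports. "The series", "measured", "known", "first", "only" and "open" are said of these compounds alone.

Measured so far in an ADME assay on microsomes from liver (Homo sapiens) for metabolic stability, read by LC-MS, using NADPH, with stated times of 10 min and 45 min, tested at 1 uM; on this read-out lower numbers stand for slow clearance and higher numbers for fast clearance:
- compound 1 `Cc1cc(C)c(CN2CCc3c(Cl)cc([C@@H](CO)[C@@H]4CCOC4)c(Cl)c3C2=O)c(=O)[nH]1`: 25.3 uL/min
- compound 2 `COC(c1cc(Cl)c2c(c1Cl)C(=O)N(Cc1c(C)cc(C)[nH]c1=O)CC2)C1CCN(C(C)=O)CC1`: 50.3 uL/min; 92.6 uL/min (2 entries)
- compound 3 `Cc1cc(C)c(CN2CCc3c(Cl)cc([C@@H](C)CO)c(Cl)c3C2=O)c(=O)[nH]1`: 12.4 uL/min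

Compound 1 gives the highest of the two single numbers here; its nearest neighbour is compound 3, and the step of a 2.0-fold lower number from compound 1 to compound 3 (0.31 log units; beyond the scatter) lies beyond the scatter. Compound 2 has no single number but a pair of entries, (the several entries of compound 2 in this assay, 50.3 uL/min; 92.6 uL/min (2 entries)), which sit higher than either of the others.

Compound 4 `Cc1cc(C)c(CN2CCc3c(Cl)cc(-c4c(C)noc4C)c(Cl)c3C2=O)c(=O)[nH]1` differs from compound 1 in one place: a group of 7 heavy atoms (5 carbon, 1 nitrogen, 1 oxygen; one five-membered aromatic ring with 2 hetero atoms) in place of a group of 8 heavy atoms (6 carbon, 2 oxygen; one five-membered non-aromatic ring with 1 hetero atom), on an aromatic carbon. The group that leaves carries a hydrogen-bond donor and two stereocentres; the 3,5-dimethyl-1,2-oxazol-4-yl group that enters has none of either and is aromatic.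

Within the data shown here, the only measured step, from compound 1 to compound 3, also trims the group on that aromatic carbon, and it moved the number down by a modest amount. Compound 4 does not simply trim that group but replaces it with a different ring type, so that step is a weak guide. Compound 1 is expected to show little change, with compound 4 estimated at 30 uL/min, between 12 uL/min and 75 uL/min, a step of a 1.2-fold higher number from compound 1 to compound 4 (0.07 log units; within the scatter) that may well stay within the scatter in this assay.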

Compound 4, intrinsic clearance in a liver preparation (reported as CLH), per the amount of preparation that the assay uses: 107 uL/min
For compound 4 the middle estimate is 3.6-fold (0.55 log units) below the measured one; the measured number lies above the stated range.
By their numbers in this assay, from the lowest: compound 3; then compound 1; then compound 4.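

This position is clearly sensitive to what it carries in this assay: with 3,5-dimethyl-1,2-oxazol-4-yl on the aromatic carbon there is a 4.2-fold higher number from compound 1 to compound 4 (0.63 log units; beyond the scatter), and against the 1-(hydroxymethyl)ethyl group there is an 8.6-fold higher number from compound 3 to compound 4 (0.94 log units; beyond the scatter), both in the opposite direction to the earlier step, a 2.0-fold lower number from compound 1 to compound 3 (0.31 log units; beyond the scatter), which had only trimmed the group. The earlier compounds shown here all carry a non-aromatic group here, so only now is it visible that an aromatic ring without a hydrogen-bond donor or stereocentre can sit on the fast-clearance side of both compound 1 and compound 3. Nothing measured in this set gives a reason for the rise.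

The change from compound 1 to compound 4 alters the ring type, the hydrogen-bond donor and the stereocentres all at once, so these compounds cannot show which of them matters. From the compounds shown here alone, it also remains open whether a plain phenyl ring, a pyridine ring or a 3,5-dimethyl-1,2-oxazol-4-yl group joined to a hydroxymethyl chain would land near compound 4 or near compound 3.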